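The source may report more compounds than this note shows. Statements on the series, on what has been measured and on what is new or still open speak of the compounds shown alone.

In a functional assay on K562 cells (Homo sapiens), read by MTT assay, with a stated time of 72 h (on this read-out higher numbers stand for weaker inhibition and lower numbers for stronger inhibition), compound 2 `COc1ncnc2c1c(-c1cccs1)cn2[C@@H]1O[C@H](CO)[C@@H](O)[C@H]1O` gives 70 nM, the lowest of the two numbers shown. Compound 1 `COc1ncnc2c1c(-c1ccoc1)cn2[C@@H]1O[C@H](CO)[C@@H](O)[C@H]1O` gives 190 nM, a step of a 2.7-fold lower number from compound 1 to compound 2 (0.43 log units; beyond the scatter). Compound 3 `CNc1ncnc2c1c(-c1cccs1)cn2[C@@H]1O[C@H](CO)[C@@H](O)[C@H]1O` is reported only as the limit > 20000 nM (the limit of > 20000 nM in this assay, at which 1 of the 3 values shown sits).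

Compound 4 `C#Cc1cn([C@@H]2O[C@H](CO)[C@@H](O)[C@H]2O)c2ncnc(OC)c12` differs from compound 2 by ethynyl in place of thiophen-2-yl on an aromatic carbon. For the measured compounds named here, the only measured step at this position is a 2.7-fold lower number from compound 1 to compound 2 (0.43 log units; beyond the scatter), a modest one; the large at least 280-fold higher number from compound 2 to compound 3 (2.45 log units; beyond the scatter) concerns a different position and does not bear on it. The change to ethynyl removes a whole ring, a bigger change than that swap of one five-membered aromatic ring for another, so a modest step is expected, more likely towards a higher number than a lower one. Compound 4 is therefore estimated at 200 nM, between 40 nM and 1000 nM, a step of a 2.9-fold higher number from compound 2 to compound 4 (0.46 log units; beyond the scatter).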

Compound 4, half-maximal inhibitory concentration: 300 nM
For compound 4 the middle estimate is 1.5-fold (0.18 log units) below the measured one, within the range that was stated.
By their numbers in this assay, from the lowest: compound 2; then compounds 1 and 4 (each within the scatter of the next). At a limit, above all of these: compound 3.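

Replacing the ring with ethynyl, which has no ring, costs only a modest step (a 4.3-fold higher number from compound 2 to compound 4 (0.63 log units; beyond the scatter)), so among the compounds shown a five-membered aromatic ring at this aromatic carbon is not needed for activity of this order. Ethynyl also cannot be told apart from furan-3-yl (a 1.6-fold higher number from compound 1 to compound 4 (0.20 log units; within the scatter)), which leaves thiophen-2-yl alone ahead of the other two groups. Nothing shown gives a cause for these steps. From the compounds shown here alone, how a phenyl ring, a longer alkyne chain or an amine would fare on this carbon stays open.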